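The source may hold more compounds than are shown below. What is called first, only, known or untested is meant among the compounds shown, and "the series" means these compounds.

Values in a functional assay on PC-3 cells (Homo sapiens) for cytotoxicity, read by WST assay, with a stated time of 72 h; a lower number here means a stronger inhibitor, a higher number a weaker inhibitor:
- compound 1 `O=C1Nc2c(ccc(F)c2F)C1(c1ccc(O)cc1)c1ccc(F)cc1`: 8.6 nM
- compound 2 `CCCOc1ccc(C2(c3ccc(O)cc3)C(=O)Nc3c2ccc(F)c3F)cc1`: > 1000 nM
- compound 3 `COc1ccc(C2(c3cccc(O)c3)C(=O)Nc3c2ccc(F)c3F)cc1`: 145 nM

Compound 1, at 8.6 nM, has the lower of the two actual numbers, and compound 3 stands at 145 nM. Compound 2 gives a limit and not a number, > 1000 nM, as noted in the limit of > 1000 nM in this assay, at which 1 of the 3 values shown sits.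

Next in the series is compound 4 `O=C1Nc2c(ccc(F)c2F)C1(c1ccncc1)c1ccc(O)cc1`, not yet measured. It carries pyridin-4-yl in place of the 4-fluorophenyl of compound 1, on a saturated ring carbon of the shared core: pyridin-4-yl in place of 4-fluorophenyl on a saturated ring carbon.

Among the compounds with values here, one measured step bears on this change: an at least 110-fold higher number from compound 1 to compound 2 (2.06 log units; beyond the scatter). It is large and rests on a limit, and it replaces fluoro with propoxy on the same aryl group. The aromatic ring itself stays in that step, whereas it is exchanged in compound 4, so the step is only an indirect guide. Within the data shown here, it shows that a change to this aryl group can raise the number well beyond the scatter, and no measured step lowers it.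

A moderate rise in this assay is therefore expected, smaller than the step to compound 2. The expected step is a 9.3-fold higher number from compound 1 to compound 4 (0.97 log units; beyond the scatter). For compound 4 the estimated value is 80 nM, with an expected range of 15 nM to 500 nM.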

Compound 4, half-maximal inhibitory concentration: 110 nM
For compound 4 the middle estimate is 1.4-fold (0.14 log units) below the measured one; low and high end bracket the measured number.
By their numbers in this assay, from the lowest: compound 1; then compounds 4 and 3 (each within the scatter of the next). At a limit, above all of these: compound 2.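

In this assay, within the data shown here, the exchange of 4-fluorophenyl for pyridin-4-yl on the saturated ring carbon gives a large rise (a 13-fold higher number from compound 1 to compound 4 (1.11 log units; beyond the scatter)), the first measured change of the aromatic ring itself at this aryl group, and one that brings in a ring nitrogen and a hydrogen-bond acceptor. The earlier step at this aryl group kept the carbon-only ring and replaced only its fluoro substituent, and compound 2 gave only a limit (> 1000 nM), so compound 4 supplies the first complete size for a change here. No measurement at hand accounts for the rise.

Only one ring exchange is shown, so it remains open whether the rise follows from losing the fluoro substituent or from entry of the ring nitrogen, which an unsubstituted phenyl at the same carbon would separate. As far as these compounds go, it is also open how other groups there would read in this assay, such as a pyrimidine, a thiophene, or a phenyl ring carrying chloro, an amine or a carboxylic acid.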